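Swapping a saturated ring for an aromatic one

The source may report more compounds than this note shows. Statements on the series, on what has been measured and on what is new or still open speak of the compounds shown alone.

Measured so far:
compound 1 `Cc1ncc([N+](=O)[O-])n1CC(O)CSC(=S)N1CCN(c2cccc(Cl)c2)CC1`: 1080000 nM
compound 2 `Cc1ncc([N+](=O)[O-])n1CC(O)CN1CCN(c2cccc(Cl)c2)CC1`: 1440000 nM
compound 3 `Cc1ncc([N+](=O)[O-])n1CC(O)CN1CCCC1`: > 5000000 nM, a limit of the assay rather than a number

All three were tested in a toxicity assay on HeLa cells (Homo sapiens) for cytotoxicity, read by MTT assay, with a stated time of 24 h; on this read-out higher numbers stand for weaker inhibition and lower numbers for stronger inhibition. For compound 3 the result is only a limit, so its true value is not known. Compound 3 therefore stands at the limit of > 5000000 nM in this assay, at which 1 of the 3 values shown sits, the upper end of what this assay reports, whereas compound 1 and compound 2 gave numbers. Compound 4 `Cc1ncc([N+](=O)[O-])n1CC(O)Cn1nccn1` is not yet measured. It differs from compound 3 by 2H-1,2,3-triazol-2-yl in place of pyrrolidin-1-yl on a saturated chain carbon, two bonds along the chain from an oxygen on a saturated carbon. Going by the values given here, no measured pair shows the effect of such a change, so no step beyond the usual scatter is expected from compound 3 to compound 4 a number no higher from compound 3 to compound 4 (the limit leaves the size open). Compound 4 is estimated at 5000000 nM, within 1500000 nM to 15000000 nM, and the assay is expected most likely to report again only a limit.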

Compound 4, half-maximal inhibitory concentration: > 5000000 nM
Compound 4 was reported as a limit; the forecaster's own chance of this, stated with the estimate: 75%; the middle value sits exactly at the limit.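

Compound 3 and compound 4 both gave only a limit rather than a number, so no step between them can be read: the limit of > 5000000 nM in this assay, at which 2 of the 4 values shown sit.

From the compounds shown here alone, whether 2H-1,2,3-triazol-2-yl in place of pyrrolidin-1-yl changes cytotoxicity at all stays open.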